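Extending a Short Chain on a Weak Inhibitor

The source may report more compounds than this note shows. Statements on the series, on what has been measured and on what is new or still open speak of the compounds shown alone.

Of the compounds shown here, two share a small fused core and have been tested in a functional assay for inhibition, with Homo sapiens as the target; a lower number here means a stronger inhibitor, a higher number a weaker inhibitor. Compound 1, with the structure `CCCc1nc(C)c2cnnc(O)n12`, gives 56800 nM in this assay, a weak result. Compound 2, with the structure `CCc1nnc(O)n2c(C)nc(C)c12`, is known in this assay only as a limit, > 48000 nM, so no exact number exists for it. This is the assay ceiling described as the limit of > 48000 nM in this assay, at which 1 of the 2 values shown sits, and it places compound 2 among the weak inhibitors together with compound 1, without saying how weak.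

The next compound, compound 3, has the structure `CCCc1nc(C)c2c(CC)nnc(O)n12` and has not yet been tested in this assay. It differs from compound 2 by ethyl in place of hydrogen on a saturated chain carbon bound to an aromatic carbon. Within the data shown here, no measured pair in this set shows what such a change does, so there is no step to lean on.

Given that both known compounds sit at the weak end, the expectation is that this change alters little: the step from compound 2 to compound 3 is estimated as a step that the limit leaves unreadable from compound 2 to compound 3, within the usual scatter. Compound 3 is therefore expected to give about 50000 nM in this assay, somewhere between 15000 nM and 150000 nM, and it may well return only a limit again.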

Compound 3, half-maximal inhibitory concentration: 15600 nM
The estimate for compound 3 lay 3.2-fold (0.51 log units) above the measured number, within the range that was stated.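

In this assay, among these compounds, ethyl in place of hydrogen on an aromatic carbon gives a 3.6-fold lower number from compound 1 to compound 3 (0.56 log units; beyond the scatter), the first exact step in this set and one that shows this aromatic carbon can carry a small carbon chain without loss of inhibition. The second change, ethyl in place of hydrogen on a saturated chain carbon bound to an aromatic carbon, is the same as turning methyl into propyl, and it gives an at least 3.0-fold lower number from compound 2 to compound 3 (0.48 log units; beyond the scatter), so both single changes that lead to compound 3 point toward a stronger inhibitor. The true size of this second step stays unknown, since compound 2 is known only as a limit: the limit of > 48000 nM in this assay, at which 1 of the 3 values shown sits.

Even so, compound 3 remains a weak inhibitor at 15600 nM, and with only one step at each place, nothing yet shows whether the trend continues with a longer chain such as butyl on the aromatic carbon. On these data alone, it is equally open how an amine or a carboxylic acid at that same carbon would compare with ethyl, so the gain cannot yet be tied to chain length alone.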